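Ring swap at the thioether carbon: pyridine to hydroxyphenyl

The source may report more compounds than this note shows. Statements on the series, on what has been measured and on what is new or still open speak of the compounds shown alone.

Three analogues of one core have been run in an assay on isolated protein for inhibition of aldehyde dehydrogenase 1A1 (Homo sapiens); on this read-out higher numbers stand for weaker inhibition and lower numbers for stronger inhibition. Compound 1 `CC(Sc1nc2c(cnn2C)c(=O)n1-c1ccccc1)c1ccccn1` gives 242 nM; compound 2 `CC(Sc1nc2c(cnn2C)c(=O)n1-c1ccccc1)c1ccncc1` gives 451 nM; compound 3 `CC(Sc1nc2c(cnn2C)c(=O)n1-c1ccccc1)c1cccnc1` gives 139 nM. Compound 3 shows the lowest number of the three, but its gap to compound 1 is small, as a 1.7-fold lower number from compound 1 to compound 3 (0.24 log units; within the scatter); only the gap to compound 2 is larger, as a 3.2-fold lower number from compound 2 to compound 3 (0.51 log units; beyond the scatter). The remaining pair, a 1.9-fold higher number from compound 1 to compound 2 (0.27 log units; within the scatter), is likewise small.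

Compound 4 `CC(Sc1nc2c(cnn2C)c(=O)n1-c1ccccc1)c1cccc(O)c1` takes the next step from compound 3: 3-hydroxyphenyl in place of pyridin-3-yl on a saturated chain carbon bound to a saturated chain carbon and a sulfur. Going by the values given here, no measured pair exchanges a pyridine for a hydroxyphenyl, so this change has no direct precedent. Among the compounds with values here, the only steps that bear on it are the three moves of the ring nitrogen around the same position, and all of them were modest or within the scatter. Within the data shown here, the hydroxyl brings a hydrogen-bond donor that no measured compound carries, so a new effect cannot be ruled out, but nothing in the numbers points in either direction.

The expected step is a 1.4-fold higher number from compound 3 to compound 4 (0.16 log units; within the scatter), that is, no change beyond the scatter. Compound 4 is therefore estimated at 200 nM, within a range from 60 nM to 700 nM.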

Compound 4, half-maximal inhibitory concentration in the aldehyde dehydrogenase 1A1 assay: 130 nM
The estimate for compound 4 lay 1.5-fold (0.19 log units) above the measured number; the measured number falls inside the stated range.
By their numbers in the aldehyde dehydrogenase 1A1 assay, from the lowest: compounds 4, 3, 1 and 2 (each within the scatter of the next, the first and the last beyond it).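

In the aldehyde dehydrogenase 1A1 assay, 3-hydroxyphenyl can replace pyridin-3-yl on a saturated chain carbon bound to a saturated chain carbon and a sulfur with no change beyond the scatter, a 1.1-fold lower number from compound 3 to compound 4 (0.03 log units; within the scatter), so a ring of carbon only serves here as well as the best-placed pyridine. Compound 4 also repeats the standing of compound 3 against the other pyridines: a 1.9-fold lower number from compound 1 to compound 4 (0.27 log units; within the scatter) stays within the scatter, while a 3.5-fold lower number from compound 2 to compound 4 (0.54 log units; beyond the scatter) goes beyond it, leaving pyridin-4-yl as the only ring clearly separated from compound 4. The swap does not come free in a physicochemical assay for solubility, using the shake flask method, in phosphate buffer, with a stated time of 24 h, at pH 7.4 (a higher number here means a more soluble compound, a lower number a less soluble compound), where the two compounds that the aldehyde dehydrogenase 1A1 assay cannot separate part clearly: the measured solubility of compound 3, 209000 nM, and of compound 4, 21000 nM, a 10-fold lower number (1.00 log units; beyond the scatter) In the physicochemical assay, compound 3 gives 209000 nM and compound 4 gives 21000 nM.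

Whether the hydroxyl or the carbon-only ring accounts for either result stays open, and a plain phenyl or a 3-methoxyphenyl at this place would separate the two. Also open, on these data alone, is whether a ring bearing an amine or a carboxylic acid could hold the level of compound 4 in the aldehyde dehydrogenase 1A1 assay and reach the level of compound 3 in the physicochemical assay.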